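Swapping the Pyridyl Attachment Point on a Shared Core

The source may hold more compounds than are shown below. What is called first, only, known or untested is meant among the compounds shown, and "the series" means these compounds.

Three compounds built on a shared core have been examined for how strongly they curb the growth of a prostate cancer cell line. In a functional assay on DU-145 cells (Homo sapiens) for cytotoxicity, read by CCK-8 assay and cell counting, with a stated time of 2 days (a lower number here means a stronger inhibitor, a higher number a weaker inhibitor), compound 1 `Oc1cccc(-c2cc(-c3ccc(Cl)cc3)nc(-c3ccccn3)c2)c1` gives 8090 nM, a weak result. Compound 2 `Oc1ccc(-c2cc(-c3ccncc3)nc(-c3ccc(Cl)cc3)c2)cc1` is recorded in this assay as "not determined" (no result reported), and compound 3 `Oc1cccc(-c2cc(-c3cccnc3)nc(-c3cccc(Cl)c3)c2)c1` is recorded there as "not determined" (no result reported), so compound 2 stands without a value of its own and cannot be placed against compound 1.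

The step followed here leads from compound 2 to compound 4 `Oc1ccc(-c2cc(-c3ccc(Cl)cc3)nc(-c3ccccn3)c2)cc1`. The change is pyridin-2-yl in place of pyridin-4-yl on an aromatic carbon. Within the data shown here, no step between two measured compounds exists in this set, so the size and direction of this move cannot be read from data; the honest expectation is a move of uncertain direction, possibly no larger than the usual scatter. Compound 4 carries the same groups as compound 1, arranged on the core in another way, so the result of compound 1 at 8090 nM serves as the nearest anchor. The estimate for compound 4 is 8000 nM, expected to fall between 2500 nM and 25000 nM.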

Compound 4, half-maximal inhibitory concentration: 22500 nM
For compound 4 the middle estimate is 2.8-fold (0.45 log units) below the measured one; measured number inside the range.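

In this assay, among these compounds, putting 4-hydroxyphenyl in place of 3-hydroxyphenyl gives a 2.8-fold higher number from compound 1 to compound 4 (0.44 log units; beyond the scatter) and so provides the first comparison in this set: moving a single hydroxyl around its phenyl ring, with the same atoms throughout, makes the compound a weaker inhibitor by more than the usual scatter. The swap of pyridin-4-yl for pyridin-2-yl itself cannot be read, since compound 2 has no value to set against compound 4. Nothing available here explains why the hydroxyl shift costs activity.

On these data alone, it remains open whether an amine or a carboxylic acid in place of the hydroxyl on that phenyl ring would give a stronger inhibitor. Also open, as far as these compounds go, is how pyridin-2-yl and pyridin-4-yl compare when everything else on the shared core stays the same.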